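The compounds below may be only part of what the source reports. "The series", "measured", "known", "first", "only" and "open" are said of these compounds alone.

Measured compounds in an assay on CHO cells for displacement of a labelled ligand from prostaglandin E2 receptor EP1 subtype (Homo sapiens); on this read-out lower numbers stand for stronger inhibition and higher numbers for weaker inhibition:
compound 1 `CCc1ccccc1N(CC(=O)NCc1ccc(OC)c(OC)c1)S(=O)(=O)c1ccc(C)cc1`, 25.1 nM
compound 2 `CCc1ccccc1N(CC(=O)NCc1ccc(Cl)cc1)S(=O)(=O)c1ccc(C)cc1`, 10 nM
compound 3 `Cc1ccc(S(=O)(=O)N(CC(=O)NCc2ccc(Cl)cc2)c2cccnc2)cc1`, a limit only

In this assay, going by the values given here, compound 1 gives 25.1 nM and compound 2 gives 10 nM; the change a 2.5-fold lower number from compound 1 to compound 2 (0.40 log units; beyond the scatter) is the one readable step in the set. For compound 3 the read-out is a limit, < 1000 nM, not a number, one of the values sitting at the limit of < 1000 nM in this assay, at which 1 of the 3 values shown sits. Hence the step that the limit leaves unreadable from compound 2 to compound 3 cannot be sized, and compound 3 stands only as somewhere under that limit.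

Compound 4 `Cc1ccc(S(=O)(=O)N(CC(=O)NCc2ccc(Cl)cc2)c2ccccn2)cc1` differs from compound 3 by pyridin-2-yl in place of pyridin-3-yl on a sulfonamide nitrogen. Among the compounds with values here, no measured step touches this change: the one sized step, a 2.5-fold lower number from compound 1 to compound 2 (0.40 log units; beyond the scatter), concerns the group on the saturated chain carbon bound to an amide-type nitrogen, and the step onto the sulfonamide nitrogen is unreadable. No step beyond the scatter is therefore expected in this assay in either direction; the working estimate is a step that the limit leaves unreadable from compound 3 to compound 4. Compound 4 is expected at 300 nM in this assay, with a range from 30 nM to 3000 nM, and a fair chance that only a limit is reported again.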

Compound 4, inhibition constant: < 1000 nM
Compound 4 gave a limit, no number (the forecaster's own chance of this, stated with the estimate: 40%); the middle value does not contradict the limit.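

No new step can be read from compound 2 or compound 3 to compound 4, as compound 3 and compound 4 are limits, not numbers, in this assay: the limit of < 1000 nM in this assay, at which 2 of the 4 values shown sit. Still open, going by these compounds, is whether pyridin-2-yl and pyridin-3-yl on the sulfonamide nitrogen differ, and how far either lies from the 2-ethylphenyl of compound 2.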